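This account rests on a few compounds, and the source may have more. Where it says the series, first, only, none or still open, it means among the compounds named here.

Among the compounds with values here, in a functional assay on UACC-62 cells (Homo sapiens) for cytotoxicity, read by sulforhodamine B assay (a higher number here means a weaker inhibitor of growth, a lower number a stronger inhibitor of growth), compound 1 `CC1=CC[C@@H]([C@@](C)(O)CCCC(C)(C)NC(=S)N/N=C\c2ccccc2)CC1` gives 12700 nM and compound 2 `CC1=CC[C@@H]([C@@](C)(O)CCCC(C)(C)NC(=S)N/N=C\c2ccccc2[N+](=O)[O-])CC1` gives 6050 nM as the lower of the two numbers so far. Within the data shown here, the only measured step is a 2.1-fold lower number from compound 1 to compound 2 (0.32 log units; beyond the scatter) and it is modest. Compound 3 `CC1=CC[C@@H]([C@@](C)(O)CCCC(C)(C)NC(=S)N/N=C\c2cccc(Cl)c2)CC1` differs from compound 2 by 3-chlorophenyl in place of 2-nitrophenyl on a carbon with a double bond to nitrogen with 3-chlorophenyl in place of 2-nitrophenyl on a carbon with a double bond to nitrogen. Among the measured compounds shown here, no measured compound carries 3-chlorophenyl, so that modest step is the only guide, and part of it may be given back. The expected change is a 1.3-fold higher number from compound 2 to compound 3 (0.12 log units; within the scatter) and no step beyond the scatter is expected. For compound 3 the estimated value is 8000 nM with 3500 nM to 18000 nM as its expected range.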

Compound 3, concentration for 50% growth inhibition: 7810 nM
Compound 3: middle estimate off by 1.0-fold (0.01 log units), on the high side; measured number inside the range.
By their numbers in this assay, from the lowest: compounds 2, 3 and 1 (each within the scatter of the next, the first and the last beyond it).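

In this assay, 3-chlorophenyl in place of 2-nitrophenyl on a carbon with a double bond to nitrogen gives a 1.3-fold higher number from compound 2 to compound 3 (0.11 log units; within the scatter), while adding a chloro group to the phenyl ring gives a 1.6-fold lower number from compound 1 to compound 3 (0.21 log units; within the scatter). Compound 3 therefore cannot be told apart from either compound 1 or compound 2, even though those two differ beyond the scatter. No evidence is available to explain this result. The compounds shown leave open whether the group itself or its place on the phenyl ring matters, since 2-nitrophenyl and 3-chlorophenyl differ in both. They also do not show how an amine or a carboxylic acid on that ring would read.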